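The compounds below may be only part of what the source reports. "The series", "measured", "known", "first", "only" and "open" are said of these compounds alone.

Measured so far:
- compound 1 `Cc1ccc(C(=O)Nc2nc(Cl)c3cn(C)nc3n2)cc1` — > 100000 nM
- compound 2 `CCOC(=O)c1nc(NC(=O)c2ccc(C)cc2)nc2nn(CC(C)(C)C)cc12` — > 100000 nM
- compound 3 `CC(C)n1cc2c(Cl)nc(NC(=O)c3ccc(C(F)(F)F)cc3)nc2n1` — 13800 nM

All three share one core and differ in the groups hung on it. In an assay on CHO cells for displacement of a labelled ligand from adenosine receptor A1 (Homo sapiens), read by scintillation counting, with a stated time of 3 h (on this read-out lower numbers stand for stronger inhibition and higher numbers for weaker inhibition), compound 1 gives > 100000 nM, which is a limit of the assay and not a number. Compound 2 likewise gives > 100000 nM in this assay, again only a limit. Within the data shown here, compound 3 is the one compound of the three with a real number, 13800 nM in this assay. Compound 1 therefore stands at the limit of > 100000 nM in this assay, at which 2 of the 3 values shown sit, so nothing finer than that is known about where it lies.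

The next compound, compound 4 `Cn1cc2c(Cl)nc(NC(=O)c3ccccc3)nc2n1`, keeps the core of compound 1 and changes one spot on the aromatic ring of the amide: hydrogen in place of methyl on an aromatic carbon. Among the measured compounds shown here, with no measured step between compounds of this kind to lean on, the change is expected to move this assay by no more than the usual scatter, in no particular direction. Compound 4 is therefore estimated to stay near the limit, at about 100000 nM, within a range from 30000 nM to 300000 nM, which means an expected step of a number no higher from compound 1 to compound 4 (the limit leaves the size open).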

Compound 4, inhibition constant: > 100000 nM
Compound 4: only a limit was reported; the forecaster's own chance of this, stated with the estimate: 70%; the middle value lies on the limit itself.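

Compound 1 and compound 4 each give only a limit in this assay, so the change from 4-methylphenyl to phenyl cannot be read as a step: the limit of > 100000 nM in this assay, at which 3 of the 4 values shown sit.

The compounds shown leave open whether this methyl group makes any difference to the read-out.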